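Chloro for isopropyl on a thiazole amide: stability outlook

A few compounds are considered here, and "the series" means these few. Any claim that something is new, unique, unknown or untested is made for them only; others in the source may bear on it.

Measured compounds:
- compound 1, `Cc1cnc(NC(=O)CCCOc2cccc(C#N)c2)s1`: 0.0667 h
- compound 2, `Cc1cnc(NC(=O)NCCOc2ccc(Cl)c(C)c2)s1`: < 0.0334 h
- compound 3, `CC(C)c1cnc(NC(=O)CCCOc2ccccc2)s1`: 0.0333 h

In an ADME assay on microsomes from liver (Mus musculus) for metabolic stability, read by LC-MS, using NADPH, tested at 1 uM (a lower number here means that the compound disappears faster, a higher number that the compound lasts longer), compound 3 gives 0.0333 h, the lowest of the two numbers reported. Compound 1 gives 0.0667 h in this assay, and the gap between compound 1 and compound 3 lies within the scatter of repeated measurements, so no order between the two can be claimed. The value of compound 2 in this assay is a limit, not a number, as recorded in the limit of < 0.0334 h in this assay, at which 1 of the 3 values shown sits.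

The not yet measured compound 4, `O=C(CCCOc1ccccc1)Nc1ncc(Cl)s1`, differs from compound 3 in one place: chloro in place of isopropyl on an aromatic carbon. Within the data shown here, no pair of measured compounds shows this change, so nothing measured speaks to its size or direction. All three measured compounds sit at the short end of what this assay reports, and the step from compound 3 to compound 4 is expected to stay within the scatter, with perhaps a slightly longer half-life. For compound 4 the estimated step is a 1.5-fold higher number from compound 3 to compound 4 (0.18 log units; within the scatter). Compound 4 is expected to give 0.05 h in this assay, with a range from 0.025 h to 0.12 h.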

Compound 4, half-life: 0.0333 h
Compound 4: the middle estimate sits 1.5-fold (0.18 log units) above what was measured; the range from low to high includes it.
By their numbers in this assay, from the lowest: compounds 3, 4 and 1 (each within the scatter of the next).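

In this assay, among these compounds, chloro in place of isopropyl on an aromatic carbon, next to the ring sulfur, gives the first reading for this change: no change at the digits printed from compound 3 to compound 4 (within the scatter). Going from the three carbons of isopropyl to the single chlorine at this place therefore leaves the half-life where it was, and this pair gives no sign that the group here sets how long the compound lasts. Compound 2 is recorded with a limit and not a number, and the two compounds of this step stand at that same short edge of the read-out, where a real difference may be hard to see: the limit of < 0.0334 h in this assay, at which 1 of the 4 values shown sits.

The compounds shown leave open whether this place would respond in a compound that lasts longer, or whether another group here, such as trifluoromethyl or an amine, would move the half-life away from that edge. The other pairs differ in more than one place, so their steps cannot be read, and the effect of a shorter chain or a carboxylic acid on the phenoxy ring also remains unknown.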